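The source may report more compounds than this note shows. Statements on the series, on what has been measured and on what is new or still open speak of the compounds shown alone.

Measured so far: compound 1 `Nc1ncnc(N2CCN(c3cccc(Cl)c3)CC2)c1[N+](=O)[O-]`, 85 nM in an assay for inhibition of ribosomal protein S6 kinase beta-1 variant D18H,T412E (Homo sapiens), read by a luciferase reporter and chemiluminescence, with a stated time of 3 h; a higher number here means a weaker inhibitor, a lower number a stronger inhibitor; compound 2 `Cc1ccc(Cl)cc1N1CCN(c2ncnc(N)c2[N+](=O)[O-])CC1`, 3 nM in this assay.

For the measured compounds named here, compound 1 stands highest of the two numbers; its only neighbour is compound 2, reached by a 28-fold lower number from compound 1 to compound 2 (1.45 log units; beyond the scatter). Compound 3 `Nc1cc(N2CCN(c3cccc(Cl)c3)CC2)ncn1` differs from compound 1 by hydrogen in place of nitro on an aromatic carbon. Going by the values given here, the single measured step, a 28-fold lower number from compound 1 to compound 2 (1.45 log units; beyond the scatter), alters a different site and says nothing about taking away the nitro; no measured step bears on this change, so the expectation rests on the structure alone and is loose. Compound 3 is therefore expected to give 600 nM, within 80 nM to 5000 nM, an estimated step of a 7.1-fold higher number from compound 1 to compound 3 (0.85 log units; beyond the scatter).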

Compound 3, half-maximal inhibitory concentration: > 2000 nM
Compound 3 ended at the assay's limit; the forecaster's own chance of this, stated with the estimate: 20%; middle value at least 3.3-fold (0.52 log units) away from the limit.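

Replacing the nitro with hydrogen on this aromatic carbon gives an at least 23-fold higher number from compound 1 to compound 3 (1.37 log units; beyond the scatter), the first sign that the core's substituent here, and not only the chlorophenyl side changed earlier, governs the reading. The reading for compound 3 is a limit of the assay, not a number: the limit of > 2000 nM in this assay, at which 1 of the 3 values shown sits. From the compounds shown here alone, the full size of the loss therefore stays unknown, and only its lower bound is fixed.

The compounds shown leave open whether a nitrile, a carboxylic acid or a plain amine at this carbon would hold the value of compound 1. They also leave open whether the methyl of compound 2 would still lower the number once the nitro is gone.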